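Amide in place of the sulfonamide: compound 4

The source may report more compounds than this note shows. Statements on the series, on what has been measured and on what is new or still open speak of the compounds shown alone.

Measured so far in an assay on isolated protein for binding affinity to Alpha-1D adrenergic receptor (Rattus norvegicus), read by radioligand binding; on this read-out lower numbers stand for stronger inhibition and higher numbers for weaker inhibition:
compound 1 `CN(c1cccc2c1CCCC2c1c[nH]cn1)S(C)(=O)=O`: 708 nM
compound 2 `CC(C)S(=O)(=O)Nc1cccc2c1CCCC2c1c[nH]cn1`: 2040 nM
compound 3 `CC(=O)Nc1cccc2c1CCCC2c1c[nH]cn1`: < 10000 nM, which is a limit of the assay and not a number.

Compound 1 holds the lowest of the two readable numbers; the nearest is compound 2, with a 2.9-fold higher number from compound 1 to compound 2 (0.46 log units; beyond the scatter). Compound 3 sits at the limit (the limit of < 10000 nM in this assay, at which 1 of the 3 values shown sits), so the steps a step that the limit leaves unreadable from compound 1 to compound 3 and a step that the limit leaves unreadable from compound 2 to compound 3 cannot be sized.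

Compound 4 `O=C(Nc1cccc2c1CCCC2c1c[nH]cn1)C(F)(F)F` is not yet measured. Relative to compound 1 the change is ((trifluoromethyl)carbonyl)amino in place of methyl(methylsulfonyl)amino on an aromatic carbon. Within the data shown here, of the measured steps, the one from compound 1 to compound 2 bears on it only loosely, as it alters the sulfonyl substituent and keeps the sulfonamide. The step from compound 1 to compound 3 is the closer analogy, compound 3 carrying the plain acetamido group, but it is unreadable. The outcome is therefore open, and the limit on compound 3 leaves room for a weaker number. A modest rise in this assay of a 4.2-fold higher number from compound 1 to compound 4 (0.63 log units; beyond the scatter) is expected. Compound 4 is estimated at 3000 nM, in a range from 600 nM to 15000 nM, with a real chance that only a limit is returned.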

Compound 4, inhibition constant: 3310 nM
Compound 4: middle estimate off by 1.1-fold (0.04 log units), on the low side, and the stated range covers the measured number.
By their numbers in this assay, from the lowest: compound 1; then compounds 2 and 4 (each within the scatter of the next).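

In this assay, among these compounds, the ((trifluoromethyl)carbonyl)amino group on this aromatic carbon gives the first readable number for a carbonyl-linked group at this position, with a 4.7-fold higher number from compound 1 to compound 4 (0.67 log units; beyond the scatter), so a sulfonyl link is not needed for a measurable number here. With a hydrogen on the nitrogen in both compounds, (trifluoromethyl)carbonyl in place of isopropylsulfonyl gives a 1.6-fold higher number from compound 2 to compound 4 (0.21 log units; within the scatter), and the two groups cannot be told apart in this assay. Compound 3 carries a limit of the assay and not a number, and the steps that involve it cannot be read: the limit of < 10000 nM in this assay, at which 1 of the 4 values shown sits.

On these data alone, what the trifluoromethyl group itself contributes relative to the methyl of the acetamido group stays open, and so does whether a methyl on the amide nitrogen would close the step that separates the amide from the methyl(methylsulfonyl)amino group. As far as these compounds go, how an amine, a carboxylic acid or a longer acyl chain on this aromatic carbon would read also remains unknown.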